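The source may report more compounds than this note shows. Statements on the series, on what has been measured and on what is new or still open speak of the compounds shown alone.

Measured compounds:
compound 1, `O=C(O)COc1ccccc1C#Cc1ccccc1Cl`, gives 747 nM
compound 2, `CCCc1ccncc1C#Cc1cc(Cl)ccc1OCC(=O)O`, gives 4.3 nM
compound 3, `O=C(O)COc1ccc(Cl)cc1C#Cc1ccccc1Cl`, gives 28 nM

All three were tested in an assay on CHO cells for displacement of a labelled ligand from prostaglandin D2 receptor 2 (Homo sapiens), read by scintillation counting; a higher number here means a weaker inhibitor, a lower number a stronger inhibitor. Compound 2 gives the lowest number of the three and is therefore the strongest inhibitor among them, with every other number lying beyond the usual scatter above it. Compound 3 comes nearest, and compound 1 lies furthest away, giving the highest number of the set. Within the data shown here, the only step in the set between two compounds that differ in a single place is a 27-fold lower number from compound 1 to compound 3 (1.43 log units; beyond the scatter), which concerns chloro in place of hydrogen on an aromatic carbon.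

The compound now in question, compound 4, `CCCCCCc1ccncc1C#Cc1cc(Cl)ccc1OCC(=O)O`, differs from compound 2 by propyl in place of hydrogen on a saturated chain carbon, three bonds along the chain from an aromatic carbon. Among the measured compounds shown here, nothing among the measured compounds speaks to a change of this kind: the one measured step involves a chloro group on a ring, not a longer saturated chain, so it gives no direction here. With no guide in the data, the expectation is that compound 4 stays close to compound 2 in this assay. Compound 4 is expected to give about 8 nM, within a range from 2 nM to 40 nM. This estimate means a step of a 1.9-fold higher number from compound 2 to compound 4 (0.27 log units; within the scatter), expected to fall within the usual scatter.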

Compound 4, inhibition constant: 43 nM
Compound 4: the middle estimate sits 5.4-fold (0.73 log units) below what was measured; measured number above the stated range.
By their numbers in this assay, from the lowest: compound 2; then compounds 3 and 4 (each within the scatter of the next); then compound 1.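

In this assay, extending the chain from propyl to hexyl gives a 10-fold higher number from compound 2 to compound 4 (1.00 log units; beyond the scatter), a step beyond the scatter. Among these compounds, this is the first sign that the number at this position depends on the length of the saturated chain, something the earlier step could not show, since it concerned a chloro group on a ring rather than this chain, and here the longer chain gives the weaker inhibitor. Nothing available explains why the added propyl has this effect, so the step stands as an observation without a known cause.

Among the compounds shown here, with only two chain lengths to compare, a single step cannot show whether the number rises gradually or abruptly, so a butyl or pentyl chain at this position would be needed to trace the trend, and a methyl or ethyl chain would show whether propyl is better than something shorter. From the compounds shown here alone, it also remains open whether the effect depends on length alone or would change if a hexyl chain ended in an amine or a carboxylic acid.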